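Adding a second chloro to the aromatic ring of compound 3

A few compounds are considered here, and "the series" means these few. Any claim that something is new, unique, unknown or untested is made for them only; others in the source may bear on it.

Measured compounds in a functional assay on LOX IMVI cells (Homo sapiens) for inhibition, read by sulforhodamine B assay, with a stated time of 48 h; on this read-out lower numbers stand for stronger inhibition of growth and higher numbers for weaker inhibition of growth:
Compound 1 `N#C/C(=C\N1CCN(C(=O)c2ccco2)C1=S)C(=O)Nc1ccc(Cl)cc1` gives 16700 nM.
Compound 2 `N#C/C(=C\N1CCN(C(=O)c2ccco2)C1=S)C(=O)c1ccccc1` gives 17900 nM.
Compound 3 `O=CN1CCN(c2ccc(Cl)cc2)C1=S` gives 11700 nM.

Compound 3 carries the lowest of the three numbers, yet its gaps to compound 1 and to compound 2 both lie within the scatter, so the three cannot be ordered. Among the measured compounds shown here, the one step among measured compounds, a 1.1-fold higher number from compound 1 to compound 2 (0.03 log units; within the scatter), exchanges a group on a carbonyl carbon and is itself within the scatter.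

Compound 4 `O=CN1CCN(c2ccc(Cl)c(Cl)c2)C1=S` differs from compound 3 by chloro in place of hydrogen on an aromatic carbon. For the measured compounds named here, no measured step touches the aromatic ring of this core, so the step from compound 1 to compound 2 bears on the change only indirectly, showing that this series has so far moved little on any change. The step of a 1.1-fold lower number from compound 3 to compound 4 (0.03 log units; within the scatter) is therefore expected to stay within the scatter. Compound 4 is estimated at 11000 nM in this assay, within a range from 4500 nM to 27000 nM.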

Compound 4, concentration for 50% growth inhibition: 9300 nM
Estimate against measurement, compound 4: 1.2-fold (0.07 log units) above; the measured number falls inside the stated range.
By their numbers in this assay, from the lowest: compounds 4, 3, 1 and 2 (each within the scatter of the next).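

In this assay, chloro in place of hydrogen on this aromatic carbon, ortho to a chloro group and meta to a group of 8 heavy atoms, gives a 1.3-fold lower number from compound 3 to compound 4 (0.10 log units; within the scatter), the first step read on the aromatic ring of this core. This position therefore accepts a second chloro with no change that can be told from the scatter, and compound 3 and compound 4 cannot be ordered. No evidence bears on this result, and nothing can be said about what lies behind it.

The compounds shown leave open whether another group on this carbon, such as an amine, a carboxylic acid or a methoxy group, would move the number beyond the scatter. They also leave open whether removing the chloro that compound 3 already carries would do so.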